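Trifluoromethyl in Place of 4-Aminopiperidin-1-yl on the Core

The source may report more compounds than this note shows. Statements on the series, on what has been measured and on what is new or still open speak of the compounds shown alone.

Three compounds have been measured in a functional assay for inhibition of sodium/hydrogen exchanger (Oryctolagus cuniculus); a higher number here means a weaker inhibitor, a lower number a stronger inhibitor:
compound 1 `Cc1cc(Br)c(S(C)(=O)=O)cc1C(=O)N=C(N)N` gives 12 nM;
compound 2 `CCSc1cc(C)c(C(=O)N=C(N)N)cc1S(C)(=O)=O` gives 5.9 nM;
compound 3 `Cc1cc(N2CCC(N)CC2)c(S(C)(=O)=O)cc1C(=O)N=C(N)N` gives 9.8 nM.

Compound 3 stands second highest of these three numbers, and its distance to each of the others is within the scatter: a 1.2-fold lower number from compound 1 to compound 3 (0.09 log units; within the scatter), and a 1.7-fold higher number from compound 2 to compound 3 (0.22 log units; within the scatter).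

Compound 4 `Cc1cc(C(F)(F)F)c(S(C)(=O)=O)cc1C(=O)N=C(N)N` differs from compound 3 in one place: trifluoromethyl in place of 4-aminopiperidin-1-yl on an aromatic carbon. Among the measured compounds shown here, no measured compound carries a trifluoromethyl group, so nothing tells directly what this change does. For the measured compounds named here, the steps that bear on it are the two that bring the 4-aminopiperidin-1-yl group in, a 1.2-fold lower number from compound 1 to compound 3 (0.09 log units; within the scatter) and a 1.7-fold higher number from compound 2 to compound 3 (0.22 log units; within the scatter), both within the scatter, while the only modest change among the three is a 2.0-fold lower number from compound 1 to compound 2 (0.31 log units; beyond the scatter). Groups of quite different make-up at this carbon have thus given similar numbers, so a step no larger than the scatter is expected, a 1.0-fold higher number from compound 3 to compound 4 (0.01 log units; within the scatter). Compound 4 is estimated at 10 nM, within 4 nM to 30 nM.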

Compound 4, half-maximal inhibitory concentration: 37 nM
For compound 4 the middle estimate is 3.7-fold (0.57 log units) below the measured one, outside the stated range (above it).
By their numbers in this assay, from the lowest: compounds 2, 3 and 1 (each within the scatter of the next, the first and the last beyond it); then compound 4.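

Among the compounds shown here, this position is less forgiving than the earlier compounds suggested, since in this assay trifluoromethyl gives a 3.8-fold higher number from compound 3 to compound 4 (0.58 log units; beyond the scatter) and a 6.3-fold higher number from compound 2 to compound 4 (0.80 log units; beyond the scatter) and a 3.1-fold higher number from compound 1 to compound 4 (0.49 log units; beyond the scatter) in the three comparisons. Very different groups matched one another closely here, yet this one stands apart from all three, so the choice of group on this carbon can change the number. Nothing available explains the shift. From the compounds shown here alone, whether the rise belongs to trifluoromethyl alone or also appears with other groups joined through carbon, such as a nitrile or a carboxylic acid, stays open.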